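The source may report more compounds than this note shows. Statements on the series, on what has been measured and on what is new or still open speak of the compounds shown alone.

Measured so far:
compound 1 `Nc1nc(Cl)c(-c2nccs2)c(N[C@@H]2C[C@H](CO)[C@@H](O)[C@H]2O)n1` — > 25000 nM (a limit)
compound 2 `CNc1ccc2sc(-c3c(Cl)nc(N)nc3N[C@@H]3C[C@H](CO)[C@@H](O)[C@H]3O)nc2c1` — 20000 nM
compound 3 `Cc1nc(NCC(C)C)nc(N[C@@H]2C[C@H](CO)[C@@H](O)[C@H]2O)c1-c1nc2ccccc2s1` — 10000 nM

In an ADME assay on cells (Homo sapiens) for cytotoxicity, read by polymerase chain reaction, with a stated time of 3 days (on this read-out lower numbers stand for higher toxicity in this test and higher numbers for lower toxicity in this test), compound 3 gives 10000 nM, the lowest of the two numbers; compound 2 gives 20000 nM, a gap within the scatter, so no order between the two is claimed. For compound 1 the entry > 25000 nM is a limit of the assay rather than a number; (the limit of > 25000 nM in this assay, at which 1 of the 3 values shown sits). Compound 4 `Cc1nc(Nc2nccs2)nc(N[C@@H]2C[C@H](CO)[C@@H](O)[C@H]2O)c1-c1nc2ccccc2s1` is not yet measured. It differs from compound 3 by 1,3-thiazol-2-yl in place of isobutyl on a nitrogen on an aromatic ring. Going by the values given here, no measured pair isolates this change, so no size is known from the data; the expectation is no step beyond the scatter, leaning slightly toward a lower number. Compound 4 is expected to give 8000 nM, between 3000 nM and 25000 nM. The expected step is a 1.3-fold lower number from compound 3 to compound 4 (0.10 log units; within the scatter).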

Compound 4, half-maximal cytotoxic concentration: 15000 nM
Beside the measured number, compound 4's estimate is 1.9-fold (0.27 log units) below it, and the stated range covers the measured number.
By their numbers in this assay, from the lowest: compounds 3, 4 and 2 (each within the scatter of the next). At a limit, above all of these: compound 1.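

In this assay, 1,3-thiazol-2-yl in place of isobutyl on a nitrogen on an aromatic ring gives a 1.5-fold higher number from compound 3 to compound 4 (0.18 log units; within the scatter) for the only pair shown that differs in one place. At this position, then, an open chain and an aromatic ring cannot be told apart on this read-out, although the entering group brings hydrogen-bond acceptors that isobutyl lacks. Nothing measured here bears on a cause for this step.

As far as these compounds go, whether a carboxylic acid or a longer chain on this nitrogen would give a step beyond the scatter remains open. So does whether the same exchange gives a similar step on another core.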